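The source may report more compounds than this note shows. Statements on the series, on what has been measured and on what is new or still open speak of the compounds shown alone.

Working notes on the series.

Two compounds have been run so far in a functional assay on HT-29 cells (Homo sapiens) for antiproliferative activity, read by MTT assay, with a stated time of 72 h; on this read-out lower numbers stand for stronger inhibition and higher numbers for weaker inhibition. Compound 1 `Cn1ccc2c(Oc3ccc(NC(=O)c4cc5cccnc5n(-c5ccc(F)cc5)c4=O)cc3)ccnc21` gives 250 nM. Within the data shown here, compound 2 `Cn1ccc2c(Oc3ccc(NC(=O)c4cc5cccnc5n(-c5ccc(Cl)cc5)c4=O)cc3)ccnc21` gives 730 nM; the only structural change between them is chloro in place of fluoro on an aromatic carbon, and the step is a 2.9-fold higher number from compound 1 to compound 2 (0.47 log units; beyond the scatter). Among the measured compounds shown here, on the two numbers available, compound 2 therefore stands with the higher number, and compound 1 is its only neighbour.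

Compound 3 `COc1ccc(-n2c(=O)c(C(=O)Nc3ccc(Oc4ccnc5c4ccn5C)cc3)cc3cccnc32)cc1` is the next member. Relative to compound 2 the change is methoxy in place of chloro on an aromatic carbon, that is, 4-chlorophenyl to 4-methoxyphenyl, the substituent sitting on an aromatic carbon of a six-membered aromatic ring of carbon only, para to a large group.

For the measured compounds named here, no measured step involves methoxy at this position. Going by the values given here, the one step that touches the same carbon, a 2.9-fold higher number from compound 1 to compound 2 (0.47 log units; beyond the scatter), shows that exchanging the halogen there moved the number by a modest amount, so the position is responsive, but the direction for methoxy cannot be read from it. The expected step from compound 2 to compound 3 is therefore a 1.5-fold lower number from compound 2 to compound 3 (0.16 log units; within the scatter), not beyond the scatter, with a wide band either side. For compound 3 the estimate in this assay is 500 nM, ranging from 150 nM to 1700 nM.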

Compound 3, half-maximal inhibitory concentration: 2050 nM
Compound 3: middle estimate off by 4.1-fold (0.61 log units), on the low side; measured number above the stated range.
By their numbers in this assay, from the lowest: compound 1; then compound 2; then compound 3.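

In this assay methoxy in place of chloro is a 2.8-fold higher number from compound 2 to compound 3 (0.45 log units; beyond the scatter) and methoxy in place of fluoro is an 8.2-fold higher number from compound 1 to compound 3 (0.91 log units; beyond the scatter), so the three groups on this aromatic carbon now fall in the order fluoro, chloro, methoxy, with every gap beyond the scatter. Until now the position had shown only one halogen exchanged for another; it now shows that a group that is not a halogen, and that brings a hydrogen-bond acceptor where chloro brings none, also raises the number, moving further from compound 1 rather than back towards it. No accompanying measurement bears on what lies behind this order.

The compounds shown leave open where a small amine, a carboxylic acid or a longer chain such as ethoxy would fall in this order, and whether any group on this carbon gives a lower number than fluoro. They also leave open whether the same order would hold with the group moved elsewhere on the ring or with a different shared core.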